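A few compounds are considered here, and "the series" means these few. Any claim that something is new, unique, unknown or untested is made for them only; others in the source may bear on it.

Values in a functional assay on DU-145 cells (Homo sapiens) for antiproliferative activity, read by WST assay, with a stated time of 3 days; a lower number here means a stronger inhibitor, a higher number a weaker inhibitor:
- compound 1 `CCCCOc1c(-c2cc(OC)c(OC)c(OC)c2)oc2ccccc2c1=O`: > 50000 nM (a limit)
- compound 2 `CCCCCOc1c(-c2cc(OC)c(OC)c(OC)c2)oc2ccccc2c1=O`: > 50000 nM (a limit)
- compound 3 `CCN(CC)CCCCOc1c(-c2cc(OC)c(OC)c(OC)c2)oc2ccccc2c1=O`: 13300 nM

Among the measured compounds shown here, compound 3 is the only member of the series with a number in this assay. The other two stand at the limit of > 50000 nM in this assay, at which 2 of the 3 values shown sit.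

The next step leads to compound 4 `CCCCN(CCCC)CCCCOc1c(-c2cc(OC)c(OC)c(OC)c2)oc2ccccc2c1=O`, which keeps the shared core and the chain but changes the amine: dibutylamino in place of diethylamino on a saturated chain carbon, four bonds along the chain from an oxygen on an aromatic ring. In words, dibutylamino replaces diethylamino on a saturated chain carbon, four bonds along the chain from an oxygen on an aromatic ring.

For the measured compounds named here, two measured steps bear on this place: an at least 3.7-fold lower number from compound 1 to compound 3 (0.57 log units; beyond the scatter) and an at least 3.7-fold lower number from compound 2 to compound 3 (0.57 log units; beyond the scatter). Both show what is seen when diethylamino enters at this carbon, but neither varies the groups on the amine nitrogen. The chain step gives no further guide, as it reads a step that the two limits leave unreadable from compound 1 to compound 2.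

Going by the values given here, the series therefore offers no measured precedent for this exchange. The working expectation in this assay is no change beyond the scatter, anchored on compound 3 at 13300 nM, with wide uncertainty in either direction.

The expected outcome is a 1.3-fold lower number from compound 3 to compound 4 (0.12 log units; within the scatter).

Compound 4 is estimated at 10000 nM, with an expected range of 2500 nM to 40000 nM.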

Compound 4, half-maximal inhibitory concentration: 15300 nM
Beside the measured number, compound 4's estimate is 1.5-fold (0.18 log units) below it; measured number inside the range.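

In this assay, dibutylamino in place of diethylamino on the saturated chain carbon gives a 1.2-fold higher number from compound 3 to compound 4 (0.06 log units; within the scatter), so the two amines read alike here even though the group grows from 5 to 9 heavy atoms. The earlier compounds shown here showed this step only for diethylamino; dibutylamino now shows it too, with an at least 3.2-fold lower number from compound 2 to compound 4 (0.51 log units; beyond the scatter) and an at least 3.2-fold lower number from compound 1 to compound 4 (0.51 log units; beyond the scatter), so within these compounds it is not tied to a single set of groups on the nitrogen. The values of compound 1 and compound 2 are limits of the assay and not numbers, which leaves the true size of both steps unknown: the limit of > 50000 nM in this assay, at which 2 of the 4 values shown sit.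

Still open, from the compounds shown here alone, is whether a smaller dimethylamino group, or a ring amine such as piperidine or morpholine, reads the same as diethylamino and dibutylamino at this carbon. Also open, going by these compounds, is how a shorter or longer chain between the aromatic oxygen and the amine would read, and whether a carboxylic acid in place of the amine would match the chains without an amine or the two amines.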